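A few compounds are considered here, and "the series" means these few. Any claim that something is new, unique, unknown or untested is made for them only; others in the source may bear on it.

Measured compounds: compound 1 `COc1cccc(CNCCCNc2ccnc3cc(Oc4ccc(F)cc4)ccc23)c1O` gives 11000 nM; compound 2 `COc1cccc(CNCCCNc2ccnc3cc(Oc4ccccc4)ccc23)c1O` gives 6800 nM; compound 3 `COc1cccc(CNCCCNc2ccnc3cc(Oc4cccc(N(C)C)c4)ccc23)c1O` gives 7300 nM.

In an ADME assay on HepG2 cells (Homo sapiens) for cytotoxicity, read by luminescence, CellTiter-Glo and ATP content, with a stated time of 72 h (a higher number here means that more compound is needed for the effect, a lower number that less compound is needed), compound 3 stands second highest of the three numbers, nearest to compound 2 and furthest from compound 1, with both gaps within the scatter. Compound 4 `COc1cccc(CNCCCNc2ccnc3cc(Cc4cc(C)cc(C)c4)ccc23)c1O` differs from compound 3 by 3,5-dimethylbenzyl in place of 3-(dimethylamino)phenoxy on an aromatic carbon. For the measured compounds named here, the steps that touch this place, a 1.5-fold lower number from compound 1 to compound 3 (0.18 log units; within the scatter) and a 1.1-fold higher number from compound 2 to compound 3 (0.03 log units; within the scatter), and also a 1.6-fold lower number from compound 1 to compound 2 (0.21 log units; within the scatter), all lie within the scatter; none of them exchanges a phenoxy group for a benzyl group, so the change has no direct precedent. With all three measured variations at this place flat, no step beyond the scatter is expected for compound 4: a 1.0-fold lower number from compound 3 to compound 4 (0.02 log units; within the scatter). Compound 4 is therefore estimated at 7000 nM, in the range 3000 nM to 16000 nM.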

Compound 4, half-maximal effective concentration: 2680 nM
Estimate against measurement, compound 4: 2.6-fold (0.42 log units) above; measured number below the stated range.
By their numbers in this assay, from the lowest: compound 4; then compounds 2, 3 and 1 (each within the scatter of the next).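

For the compounds shown here, putting 3,5-dimethylbenzyl in place of the phenoxy groups is the first change at this place to go beyond the scatter in this assay, with a 2.7-fold lower number from compound 3 to compound 4 (0.44 log units; beyond the scatter) and a 2.5-fold lower number from compound 2 to compound 4 (0.40 log units; beyond the scatter) and a 4.1-fold lower number from compound 1 to compound 4 (0.61 log units; beyond the scatter) all pointing the same way. All three steps are modest, and each changes the linking atom and the ring substituents together. No measurement at hand accounts for the shift.

From the compounds shown here alone, whether the carbon link or the two methyl groups carry the step stays open. Unsubstituted benzyl or a 3,5-dimethylphenoxy group at this place would separate them.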